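Two limits and a trifluoromethyl swap

A few compounds are considered here, and "the series" means these few. Any claim that something is new, unique, unknown or untested is made for them only; others in the source may bear on it.

In an ADME assay on Raji cells (Homo sapiens) for cytotoxicity, read by luminescence, with a stated time of 72 h (a higher number here means that more compound is needed for the effect, a lower number that less compound is needed), compound 1 (`CCOC(=O)c1c(-c2cccc(OC)c2)[nH]c2cc(OC)c(F)cc2c1=O`) gives > 21500 nM as a limit of the assay. Compound 2 (`CCOC(=O)c1c(-c2cccc(Oc3ccccc3)c2)[nH]c2cc(OC)c(F)cc2c1=O`) gives > 21500 nM as a limit too, so it has no number of its own. Compound 3 (`CCOC(=O)c1c(-c2cccc(OC(F)(F)F)c2)[nH]c2cc(OC)c(F)cc2c1=O`) carries trifluoromethyl in place of phenyl on an oxygen on an aromatic ring. For the measured compounds named here, the one measured step bearing on this (a step that the two limits leave unreadable from compound 1 to compound 2) has no readable size, and both values sit at one limit (the limit of > 21500 nM in this assay, at which 2 of the 2 values shown sit). From that step, no change beyond the scatter is expected in this assay and no direction can be given. The estimated step (a step that the limit leaves unreadable from compound 2 to compound 3) is correspondingly small. Compound 3 is expected at 25000 nM with an estimated range (12000 nM to 50000 nM).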

Compound 3, half-maximal effective concentration: > 21500 nM
Compound 3 was reported as a limit; the forecaster's own chance of this, stated with the estimate: 80%; the middle value lies beyond the limit too.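

No step among compound 1, compound 2 and compound 3 can be read, as all three give only a limit: the limit of > 21500 nM in this assay, at which 3 of the 3 values shown sit.

The compounds shown leave open whether phenoxy, trifluoromethoxy or the methyl on that oxygen makes any difference in this assay.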